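Estimating Compound 4 from Its Closest Measured Neighbours

This account rests on a few compounds, and the source may have more. Where it says the series, first, only, none or still open, it means among the compounds named here.

Measured compounds:
- compound 1 `COc1ccc(OC)c(/C=N/NC(=O)Nc2ccc(Oc3ccnc(-c4nncn4CCN(C)C)c3)c(F)c2)c1` gives 1510 nM
- compound 2 `CN(C)CCn1cnnc1-c1cc(Oc2ccc(NC(=O)N/N=C/c3ccccc3)cc2F)ccn1` gives 2730 nM
- compound 3 `Cn1ncnc1-c1cc(Oc2ccc(NC(=O)N/N=C/c3ccccc3)cc2F)ccn1` reaches only a limit, > 100000 nM

In a functional assay on MKN-45 cells (Homo sapiens) for cytotoxicity, read by MTT assay, with a stated time of 72 h (on this read-out lower numbers stand for stronger inhibition and higher numbers for weaker inhibition), compound 2 and compound 1 sit close together, as a 1.8-fold higher number from compound 1 to compound 2 (0.26 log units; within the scatter) shows. Compound 3 sits at the limit of > 100000 nM in this assay, at which 1 of the 3 values shown sits. The change from compound 2 to compound 3 was large, an at least 36-fold higher number from compound 2 to compound 3 (1.56 log units; beyond the scatter), but it touches a different part of the molecule. Compound 4 `CN(C)CCn1cnnc1-c1cc(Oc2ccc(NC(=O)N/N=C/c3cc(Br)c(O)c(Br)c3)cc2F)ccn1` differs from compound 2 by 3,5-dibromo-4-hydroxyphenyl in place of phenyl on a carbon with a double bond to nitrogen. Among the compounds with values here, the only measured step at this carbon, from compound 1 to compound 2, stayed within the scatter, so for compound 4 the expected step is a 1.2-fold lower number from compound 2 to compound 4 (0.09 log units; within the scatter). Compound 4 is therefore estimated at 2200 nM, with a likely range from 700 nM to 7000 nM.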

Compound 4, half-maximal inhibitory concentration: 4320 nM
Estimate against measurement, compound 4: 2.0-fold (0.29 log units) below; low and high end bracket the measured number.
By their numbers in this assay, from the lowest: compounds 1, 2 and 4 (each within the scatter of the next, the first and the last beyond it). At a limit, above all of these: compound 3.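

In this assay, replacing phenyl with the larger 3,5-dibromo-4-hydroxyphenyl, which brings two bromines and a hydrogen-bond donor, stays within the scatter (a 1.6-fold higher number from compound 2 to compound 4 (0.20 log units; within the scatter)). Set against 2,5-dimethoxyphenyl, the same group gives the first modest step at this carbon that lies beyond the scatter (a 2.9-fold higher number from compound 1 to compound 4 (0.46 log units; beyond the scatter)). Nothing measured here accounts for that gap. A 4-hydroxyphenyl or a 3,5-dibromophenyl group on this carbon would separate the contribution of the hydroxyl from that of the bromines. Going by these compounds, how an amine on this ring would read remains open.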